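The source may hold more compounds than are shown below. What is called first, only, known or untested is meant among the compounds shown, and "the series" means these compounds.

Compound 1, `COc1ccc(CN2C(=O)C(=O)c3cc(-c4ccc(OC)c(OC)c4)ccc32)cc1`: 260 nM. Compound 2, `CCOC(=O)/C=C1\C(=O)N(Cc2ccc(OC)cc2)c2ccc(-c3ccc(OC)cc3)cc21`: 1240 nM.

Both compounds were examined in a functional assay on K562 cells (Homo sapiens) for antiproliferative activity, read by MTT assay, with a stated time of 48 h; a higher number here means a weaker inhibitor, a lower number a stronger inhibitor. Compound 2 gives the higher of the two numbers, and compound 1 lies well away from it, beyond the scatter. Compound 3, `COc1ccc(CN2C(=O)/C(=C\c3ccc(C(F)(F)F)cc3)c3cc(-c4ccc(OC)cc4)ccc32)cc1`, is not yet measured. It differs from compound 2 in one place: 4-(trifluoromethyl)phenyl in place of ethoxycarbonyl on a double-bonded chain carbon bound to a double-bonded ring carbon. Among the measured compounds shown here, no measured pair shows this change, so the size of the step from compound 2 to compound 3 is open. A modest decrease is expected, and compound 3 is estimated at 600 nM, with a range from 150 nM to 2500 nM, which means an expected step of a 2.1-fold lower number from compound 2 to compound 3 (0.32 log units; beyond the scatter).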

Compound 3, half-maximal inhibitory concentration: 1900 nM
Compound 3: the middle estimate sits 3.2-fold (0.50 log units) below what was measured; measured number inside the range.
By their numbers in this assay, from the lowest: compound 1; then compounds 2 and 3 (each within the scatter of the next).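

On a double-bonded chain carbon bound to a double-bonded ring carbon, 4-(trifluoromethyl)phenyl replaces ethoxycarbonyl in this assay with a step that stays within the scatter: a 1.5-fold higher number from compound 2 to compound 3 (0.19 log units; within the scatter). At this place, then, the number holds when the hydrogen-bond acceptors of ethoxycarbonyl are lost and a larger aromatic ring enters. Nothing shown here gives a measured reason for this result.

Going by these compounds, whether a carboxylic acid, an amine or an unsubstituted phenyl at this place would hold the number as well remains open.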